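This account rests on a few compounds, and the source may have more. Where it says the series, first, only, none or still open, it means among the compounds named here.

Compound 1 `COc1cccc(NC(=O)c2nnn(Cc3ccc(C#N)cc3)c2N)c1`: 2.5 mL.min-1.g-1
Compound 2 `COc1cccc(NC(=O)c2nnn(Cc3cc(C)on3)c2N)c1`: 2.6 mL.min-1.g-1

Both values come from an ADME assay on microsomes from liver (Mus musculus, strain CD1) for metabolic stability, read by HPLC, using NADPH, with a stated time of 30 min; a higher number here means faster removal of the compound, a lower number slower removal. Going by the values given here, compound 2 sits level with the only other measured compound, the step being a 1.0-fold higher number from compound 1 to compound 2 (0.02 log units; within the scatter). Compound 3 `COc1cccc(NC(=O)c2nnn(Cc3ccc(C4CC4)cc3)c2N)c1` differs from compound 2 in one place: 4-cyclopropylphenyl in place of 5-methyl-1,2-oxazol-3-yl on a saturated chain carbon bound to an aromatic nitrogen. Among the compounds with values here, the only measured step at that place is the small one above, a 1.0-fold higher number from compound 1 to compound 2 (0.02 log units; within the scatter), but 4-cyclopropylphenyl played no part in it, so it guides only loosely. A small rise, not clearly beyond the scatter, is therefore expected: a 1.3-fold higher number from compound 2 to compound 3 (0.13 log units; within the scatter). For compound 3 the estimated value is 3.5 mL.min-1.g-1, with an expected range of 1.5 mL.min-1.g-1 to 8 mL.min-1.g-1.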

Compound 3, intrinsic clearance in microsomes: 4.9 mL.min-1.g-1
Beside the measured number, compound 3's estimate is 1.4-fold (0.15 log units) below it, within the range that was stated.
By their numbers in this assay, from the lowest: compounds 1, 2 and 3 (each within the scatter of the next).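

Putting 4-cyclopropylphenyl on the saturated chain carbon bound to an aromatic nitrogen gives a 1.9-fold higher number from compound 2 to compound 3 (0.28 log units; within the scatter) in this assay and so does not clearly separate it from 5-methyl-1,2-oxazol-3-yl. Cyclopropyl in place of cyano on an aromatic carbon gives a 2.0-fold higher number from compound 1 to compound 3 (0.29 log units; within the scatter) and is also not a clear change, so all three groups tried at this place read alike in this assay. No supporting measurement bears on these numbers. On these data alone, whether an amine, a carboxylic acid or a longer chain at this place would give a step beyond the scatter remains open.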